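A few compounds are considered here, and "the series" means these few. Any claim that something is new, unique, unknown or untested is made for them only; others in the source may bear on it.

Measured so far in a functional assay on the whole organism for agonist activity, with Mus musculus as the target (a higher number here means that more compound is needed for the effect, a lower number that less compound is needed), for the series:
- compound 1 `CC(=O)N(C)CC#CCn1ccnc1` gives 1.4 mg/kg
- compound 2 `O=C1NCCN1CC#CCn1ccnc1` gives 17.3 mg/kg
- compound 3 `Cc1cncn1CC#CCN1CCNC1=O` gives > 100 mg/kg as a limit

Compound 2, at 17.3 mg/kg here, holds the higher of the two true numbers, and compound 1 lies lower by a gap beyond the scatter. Compound 3 has only a limit, not a number.

Compound 4 `CN(C)CC#CCN1CCNC1=O` is the next case, with this change from compound 2: dimethylamino in place of 1H-imidazol-1-yl on a saturated chain carbon bound to a triple-bonded carbon in the structure. Going by the values given here, no measured step exchanges the leaving group outright. The nearest is an at least 5.7-fold higher number from compound 2 to compound 3 (0.76 log units; beyond the scatter) on that same group, and it rests on a limit. Removing that group is therefore expected to bring a modest move towards a lower number, with wide uncertainty. The expected step is a 3.5-fold lower number from compound 2 to compound 4 (0.54 log units; beyond the scatter) in this estimate. For compound 4 the estimated value is 5 mg/kg within a range of 0.8 mg/kg to 40 mg/kg in this assay testing.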

Compound 4, dose for half-maximal effect: 9.7 mg/kg
For compound 4 the middle estimate is 1.9-fold (0.29 log units) below the measured one, within the range that was stated.
By their numbers in this assay, from the lowest: compound 1; then compounds 4 and 2 (each within the scatter of the next). At a limit, above all of these: compound 3.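

In this assay the exchange at this place gives a 1.8-fold lower number from compound 2 to compound 4 (0.25 log units; within the scatter) and so shows that the aromatic ring of 1H-imidazol-1-yl can give way to dimethylamino, which has no ring, without a move beyond the scatter. The earlier compounds shown here showed only a change on that ring. For compound 3 there is still a limit rather than a number: the limit of > 100 mg/kg in this assay, at which 1 of the 4 values shown sits.

From the compounds shown here alone, it remains open whether diethylamino or pyrrolidin-1-yl on the same carbon stays in this range, and whether dimethylamino holds up on the core of compound 1.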